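The compounds below may be only part of what the source reports. "The series", "measured", "known", "first", "only" and "open" are said of these compounds alone.

Series notes. Of the compounds shown here, three have been measured so far in a functional assay on U-251 cells (Homo sapiens) for cytotoxicity, read by sulforhodamine B assay, with a stated time of 48 h, tested at 0.01 uM; a higher number here means a weaker effect of the compound at the concentration tested, a lower number a stronger effect. Compound 1 `COc1cc(-c2cc(/C=C/C(=O)c3ccc(Cl)c(Cl)c3)[nH]n2)cc(OC)c1OC` gives 97% in this assay. Compound 2 `COc1ccc(-c2cc(/C=C/C(=O)c3ccc(N)cc3)[nH]n2)cc1` gives 97%, and compound 3 `COc1cc(C(=O)/C=C/c2cc(-c3cc(OC)c(OC)c(OC)c3)n[nH]2)cc(OC)c1OC` gives 96%. Compound 1 stands level with compound 2 at the digits shown, the two together the highest of the three numbers; the gap to compound 3 lies within the scatter, so the three results cannot be told apart at this concentration, and none of them shows a marked effect.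

Compound 4 `COc1cc(-c2cc(/C=C/C(=O)c3ccc(F)c(F)c3)[nH]n2)cc(OC)c1OC` has not yet been measured. It differs from compound 1 in one place: 3,4-difluorophenyl in place of 3,4-dichlorophenyl on a carbonyl carbon. Among the measured compounds shown here, no pair of measured compounds carries this exchange, so the expectation rests on the three values alone, all of which sit close together. Compound 4 is expected to give 96% in this assay, within 90% to 100%. The expected a number 1 percentage points lower from compound 1 to compound 4 (within the scatter) is none beyond the scatter, because compound 1 already stands at 97% with little room to move upward.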

Compound 4, a percentage reported as activity, at one concentration (the size of the read-out at that concentration, not a potency): 97%
Beside the measured number, compound 4's estimate is 1 percentage points below it; the measured number falls inside the stated range.
By their numbers in this assay, from the lowest: compounds 3, 1, 2 and 4 (each within the scatter of the next).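

With the 3,4-difluorophenyl group in place of the 3,4-dichlorophenyl group on a carbonyl carbon, this assay gives no change at the digits printed from compound 1 to compound 4 (within the scatter). Among the compounds shown here, this is the first single-place comparison, and it shows that this exchange of one halogen pair for the other leaves the read-out unresolved from that of the parent at this one concentration. Both compounds sit at the weak-effect end of the scale, so the step gives no sign that this position responds to the exchange under these conditions, though it cannot show how the pair would compare where a marked effect appears. No measurement at hand explains the result.

As far as these compounds go, whether a nitrile or a carboxylic acid on the carbonyl-bound phenyl ring would shift the read-out remains open. Also open, from the compounds shown here alone, is whether compound 1 and compound 4 separate at any other concentration.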